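From 2-chlorobenzyl to 4-(trifluoromethyl)benzyl in the series

A few compounds are considered here, and "the series" means these few. Any claim that something is new, unique, unknown or untested is made for them only; others in the source may bear on it.

Among the measured compounds shown here, in a functional assay on HCT-116 cells (Homo sapiens) for antiproliferative activity, read by MTT assay, with a stated time of 24 h (a higher number here means a weaker inhibitor, a lower number a stronger inhibitor), compound 1 (`C=CCOc1ccc2c(=O)c(-c3cc(OC)c(OC)cc3OC)coc2c1`) gives 6600 nM and compound 2 (`COc1cc(OC)c(-c2coc3cc(OCc4ccccc4Cl)ccc3c2=O)cc1OC`) gives 2450 nM, the lower of the only two numbers so far. Compound 3 (`COc1cc(OC)c(-c2coc3cc(OCc4ccc(C(F)(F)F)cc4)ccc3c2=O)cc1OC`) keeps the shared core and differs from compound 2 in one group: 4-(trifluoromethyl)phenyl in place of 2-chlorophenyl on a saturated chain carbon bound to an oxygen on an aromatic ring. In words, 4-(trifluoromethyl)phenyl stands in place of 2-chlorophenyl on a saturated chain carbon bound to an oxygen on an aromatic ring. For the measured compounds named here, only one measured step bears on this, and only indirectly: a 2.7-fold lower number from compound 1 to compound 2 (0.43 log units; beyond the scatter), with 2-chlorophenyl in place of vinyl at that same place. That step compares vinyl with a substituted phenyl, whereas the new change exchanges one substituted phenyl for another. Going by the values given here, no measured pair in this assay shows what such an exchange does, so no direction can be argued from the data, and no change beyond the scatter is expected. The estimated step is a 1.1-fold lower number from compound 2 to compound 3 (0.03 log units; within the scatter). For compound 3 the expected value is 2300 nM, with an estimated range of 800 nM to 6500 nM.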

Compound 3, half-maximal inhibitory concentration: 2440 nM
For compound 3 the middle estimate is 1.1-fold (0.03 log units) below the measured one; the range from low to high includes it.
By their numbers in this assay, from the lowest: compounds 3 and 2 (each within the scatter of the next); then compound 1.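

In this assay the exchange of one substituted phenyl for another on a saturated chain carbon bound to an oxygen on an aromatic ring gives a 1.0-fold lower number from compound 2 to compound 3 (0.00 log units; within the scatter) and so does not separate 2-chlorophenyl from 4-(trifluoromethyl)phenyl, even though the entering group is the larger by heavy atoms. The earlier compounds shown here offered only one substituted phenyl against vinyl, whereas a 2.7-fold lower number from compound 1 to compound 3 (0.43 log units; beyond the scatter) now stands with a 2.7-fold lower number from compound 1 to compound 2 (0.43 log units; beyond the scatter) and shows the lower number against compound 1 holding for both substituted phenyl groups. Nothing available accounts for the two phenyl groups reading alike or for their difference from vinyl.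

Still open, as far as these compounds go, is whether the lower numbers against compound 1 depend on any substituent on the phenyl ring, which a plain benzyl group would test. Also open, from the compounds shown here alone, is how this place responds to a longer saturated chain without an aromatic ring, or to a benzyl group carrying an amine or a carboxylic acid.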